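The source may hold more compounds than are shown below. What is called first, only, known or untested is meant among the compounds shown, and "the series" means these compounds.

Compound 1 `Cc1ccc(S(=O)(=O)c2n[nH]c3ccc(N4CCN(C)CC4)cc23)cc1` was tested in a functional assay on HeLa cells for antagonist activity at 5-hydroxytryptamine receptor 6 (Homo sapiens) (on this read-out higher numbers stand for weaker inhibition and lower numbers for stronger inhibition), and in that assay compound 1 gives 112 nM. Within the data shown here, of the two compounds measured so far, compound 1 has the higher of the two numbers, which on this read-out means the weaker inhibition. The other measured compound is compound 2 `CCn1nc(S(=O)(=O)c2cccc3ccccc23)c2cc(N3CCN(C)CC3)ccc21`, which differs from compound 1 in several places at once, so no single structural change can be read from the pair; in this assay compound 2 gives 1.7 nM, a much lower number, and the gap between the two lies well beyond the scatter.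

Compound 3 `CN1CCN(c2ccc3[nH]nc(S(=O)(=O)c4ccc(Cl)cc4)c3c2)CC1` keeps the core of compound 1 and differs from it in a single place: chloro in place of methyl on an aromatic carbon. Among the measured compounds shown here, no measured pair shows what this exchange does in this assay, so the expectation rests on the modest size of the change alone. The expected step is a 1.1-fold lower number from compound 1 to compound 3 (0.05 log units; within the scatter), which amounts to no change beyond the scatter in either direction. Compound 3 is therefore expected to give about 100 nM, with a likely range from 40 nM to 300 nM.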

Compound 3, half-maximal inhibitory concentration: 108 nM
Estimate against measurement, compound 3: 1.1-fold (0.03 log units) below; the range from low to high includes it.
By their numbers in this assay, from the lowest: compound 2; then compounds 3 and 1 (each within the scatter of the next).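

In this assay, among these compounds, the change from 4-methylphenyl to 4-chlorophenyl gives a 1.0-fold lower number from compound 1 to compound 3 (0.02 log units; within the scatter) and so provides the first measured pair that differs in only one place. At this position, on an aromatic carbon para to a large group, methyl and chloro cannot be told apart on this read-out, even though one group is built on carbon and the other is a halogen; each is a single heavy atom with no ring and no net charge, and neither adds a hydrogen-bond donor or acceptor. Nothing available here explains why the two groups give matching numbers, so the result describes what happens without revealing the reason.

Because this exchange keeps the count of heavy atoms the same, it leaves open whether the position would tolerate a bigger or quite different group, such as methoxy, an amine or a carboxylic acid. It also leaves open whether chloro and methyl would still match on a compound carrying the ethyl group of compound 2, since this single pair speaks only for the core of compound 1.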